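The compounds below may be only part of what the source reports. "The series", "measured", "known", "first", "only" and "open" are said of these compounds alone.

Compound 1 `ClCc1ccccc1Cn1cnc2c(Cl)nc(Cl)nc21` and compound 2 `ClCc1cccc(Cn2cnc3c(Cl)nc(Cl)nc32)c1` share the same atoms joined differently; how their two cores differ is not broken down here. In a functional assay on OVCAR-4 cells (Homo sapiens) for cytotoxicity, read by sulforhodamine B assay, with a stated time of 48 h (on this read-out higher numbers stand for weaker inhibition of growth and lower numbers for stronger inhibition of growth), compound 1 gives 1770 nM, while compound 2 gives 5490 nM, the highest number of the three measured compounds. Compound 3 `Nc1nc(Cl)c2ncn(Cc3ccccc3CCl)c2n1` is derived from compound 1 by the change (amino in place of chloro on an aromatic carbon), and in this assay compound 3 gives 2460 nM; the step of a 1.4-fold higher number from compound 1 to compound 3 (0.14 log units; within the scatter) is small. Going by the values given here, compound 4 `Nc1nc(Cl)c2ncn(Cc3cccc(CCl)c3)c2n1` is the unmeasured partner of compound 2, made by the change (amino in place of chloro on an aromatic carbon), which is the same change in the same place as the one from compound 1 to compound 3. Because the step of a 1.4-fold higher number from compound 1 to compound 3 (0.14 log units; within the scatter) stayed within the scatter, a step of similar size, a 1.4-fold higher number from compound 2 to compound 4 (0.15 log units; within the scatter), is expected from compound 2 to compound 4 in this assay, with the uncertainty that a single precedent carries. For compound 4 in this assay the estimate is 7700 nM, expected to lie between 3500 nM and 17000 nM.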

Compound 4, concentration for 50% growth inhibition: 1950 nM
Compound 4: middle estimate off by 3.9-fold (0.60 log units), on the high side; the measured number lies below the stated range.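

In this assay, amino in place of chloro on an aromatic carbon gives a 2.8-fold lower number from compound 2 to compound 4 (0.45 log units; beyond the scatter), and this does not match the step seen for the same change on the core of compound 1: the same change on two cores in this assay, a 1.4-fold higher number (0.14 log units; within the scatter) from compound 1 to compound 3 and a 2.8-fold lower number (0.45 log units; beyond the scatter) from compound 2 to compound 4, 3.9-fold (0.59 log units) apart, beyond the scatter of two such steps This shows that, among the compounds shown, the effect of this change on growth inhibition did not carry over from one core to the other, so a step measured on one of these cores was a poor guide to the step on the other. Going by these compounds alone, it does not show why the two steps part, and with only one pair of compounds on each core, it says nothing about how the change would behave on any further core.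

The compounds shown leave open whether a methylamino or a methoxy group in place of the same chloro would also give steps that differ between the two cores. They also leave open how either core would respond if a hydroxymethyl group stood in place of the chloromethyl group.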